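Phenylsulfonyl in Place of Cyanophenylcarbonyl: Cytotoxicity Outlook

This account rests on a few compounds, and the source may have more. Where it says the series, first, only, none or still open, it means among the compounds named here.

Compound 1 `CC(C)(C)C(=O)Nc1ncc(C(Oc2ccc3cc(Br)ccc3c2)c2ccc(Cl)cc2)s1` — "not toxic" (no number reported)
Compound 2 `O=C(Nc1ncc(C(Oc2ccc3cc(Br)ccc3c2)c2ccc(Cl)cc2)s1)c1ccccc1` — "not toxic" (no number reported)
Compound 3 `N#Cc1cccc(C(=O)Nc2ncc(C(Oc3ccc4cc(Br)ccc4c3)c3ccc(Cl)cc3)s2)c1` — > 50000 nM

Of the compounds shown here, three on a shared core have been tested in an ADME assay on HepG2 2.2.15 cells (Homo sapiens) for cytotoxicity; on this read-out lower numbers stand for higher toxicity in this test and higher numbers for lower toxicity in this test. Compound 1 is recorded as "not toxic" (no number reported) and compound 2 as "not toxic" (no number reported), so neither carries a number. For compound 3 the read-out in this assay is a limit, > 50000 nM, not a measured value. Going by the values given here, compound 3 therefore stands at the limit of > 50000 nM in this assay, at which 1 of the 3 values shown sits, and no single number is available for any of the three, so no step between measured compounds can be sized.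

Compound 4 `O=S(=O)(Nc1ncc(C(Oc2ccc3cc(Br)ccc3c2)c2ccc(Cl)cc2)s1)c1ccccc1` is the next entry: phenylsulfonyl in place of (3-cyanophenyl)carbonyl on a nitrogen on an aromatic ring. Among the compounds with values here, with no measured step to lean on, the expectation rests only on where compound 3 sits. The step from compound 3 to compound 4 in this assay is expected to be none beyond the scatter, a number no higher from compound 3 to compound 4 (the limit leaves the size open), with the outcome most likely reported again as a limit. Compound 4 is estimated at 50000 nM in this assay, within a range of 25000 nM to 100000 nM.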

Compound 4, half-maximal cytotoxic concentration: > 50000 nM
Compound 4 gave a limit, no number; the forecaster's own chance of this, stated with the estimate: 70%; the middle value lies on the limit itself.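

In this assay, going by these compounds alone, compound 3 and compound 4 both end in a limit, so no step between them can be read. The compounds shown leave open whether phenylsulfonyl and (3-cyanophenyl)carbonyl on a nitrogen on an aromatic ring differ at all, for both results rest on one limit: the limit of > 50000 nM in this assay, at which 2 of the 4 values shown sit.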